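A few compounds are considered here, and "the series" means these few. Any claim that something is new, unique, unknown or untested is made for them only; others in the source may bear on it.

Of the compounds shown here, three that share one core have been tested in a functional assay on SK-MEL-2 cells (Homo sapiens) for inhibition, read by sulforhodamine B assay, with a stated time of 48 h, tested at 10 uM; on this read-out higher numbers stand for more inhibition at the one concentration tested (going by the name of the read-out) and lower numbers for less inhibition. Compound 1 `c1ccc(-c2cn3ccnc3c(-c3ccc4ncn(C5CCCCC5)c4c3)n2)cc1` carries an unsubstituted phenyl ring and gives 16.5%. Compound 2 `COc1ccc(-c2cn3ccnc3c(-c3ccc4ncn(C5CCCCC5)c4c3)n2)cc1` bears a methoxy group on that ring and gives 94.3%, the highest of the three numbers. Compound 3 `Fc1ccc(-c2cn3ccnc3c(-c3ccc4ncn(C5CCCCC5)c4c3)n2)cc1` carries a fluoro group instead and gives 9.82%. The step of a number 77.8 percentage points higher from compound 1 to compound 2 (beyond the scatter) is large, whereas the step of a number 6.7 percentage points lower from compound 1 to compound 3 (within the scatter) is small. Compound 2 therefore stands well apart from both neighbours: its nearest is compound 1, and its furthest is compound 3, reached by the step of a number 84.5 percentage points lower from compound 2 to compound 3 (beyond the scatter).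

Compound 4 `Clc1ccc(-c2cn3ccnc3c(-c3ccc4ncn(C5CCCCC5)c4c3)n2)cc1` has not yet been measured. It differs from compound 2 by chloro in place of methoxy on an aromatic carbon, a single-atom substituent entering where methoxy leaves, on the same aromatic carbon para to a large group. Among the measured compounds shown here, the one measured step that removes methoxy in favour of such a substituent, from compound 2 to compound 3, is a large fall, and the step from compound 1 to compound 3 shows that the bare ring and the fluoro ring sit at about the same low level. A similarly large fall in this assay is therefore expected for compound 4, namely a number 74.3 percentage points lower from compound 2 to compound 4 (beyond the scatter). Compound 4 is estimated at 20%, within a range from 5% to 55%.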

Compound 4, a percentage reported as inhibition, at one concentration (the size of the read-out at that concentration, not a potency): 10.9%
Estimate against measurement, compound 4: 9.1 percentage points above; the range from low to high includes it.
By their numbers in this assay, from the lowest: compounds 3, 4 and 1 (each within the scatter of the next); then compound 2.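

In this assay the change from 4-methoxyphenyl to 4-chlorophenyl gives a number 83.4 percentage points lower from compound 2 to compound 4 (beyond the scatter) and so repeats, with a second single-atom substituent, the large fall already seen with fluoro on this aromatic carbon para to a large group. Chloro and fluoro cannot be told apart here, as the step of a number 1.1 percentage points higher from compound 3 to compound 4 (within the scatter) shows, and chloro and hydrogen cannot be told apart either, as the step of a number 5.6 percentage points lower from compound 1 to compound 4 (within the scatter) shows, so the low level is now shared by three different groups and the high reading belongs to methoxy alone among these four compounds. The data offered here give no explanation for why methoxy stands apart from hydrogen, fluoro and chloro.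

From the compounds shown here alone, what remains open is which part of methoxy matters, since a hydroxy group would keep the oxygen without the methyl, while an ethyl group would keep a chain of similar length without the oxygen. Ethoxy or a dimethylamino group at the same place would show whether the high reading extends beyond methoxy to other groups, and none of these four compounds can answer that.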